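Amide cap change carried from one core onto another

This account rests on a few compounds, and the source may have more. Where it says the series, first, only, none or still open, it means among the compounds named here.

Compound 1 `O=C(c1ccc(F)cc1)N1CCC(NCCSC(c2ccc(F)cc2)c2ccc(F)cc2)CC1` is the reference; in an assay on membranes from Cortex for displacement of a labelled ligand from Sigma non-opioid intracellular receptor 1 (Cavia porcellus), read by scintillation counting, with a stated time of 120 min (on this read-out lower numbers stand for stronger inhibition and higher numbers for weaker inhibition), compound 1 gives 32.1 nM. Compound 3 `CC(C)(C)C(=O)N1CCC(NCCSC(c2ccc(F)cc2)c2ccc(F)cc2)CC1` carries the change tert-butyl in place of 4-fluorophenyl on a carbonyl carbon and in this assay compound 3 gives 163 nM, a step of a 5.1-fold higher number from compound 1 to compound 3 (0.71 log units; beyond the scatter). Compound 2 `O=C(c1ccc(F)cc1)N1CCC(NCC[S+]([O-])C(c2ccc(F)cc2)c2ccc(F)cc2)CC1` rests on a different core; how the core of compound 2 differs from that of compound 1 is not broken down here. In this assay compound 2 gives 1440 nM, the highest number of the three measured. Compound 4 `CC(C)(C)C(=O)N1CCC(NCC[S+]([O-])C(c2ccc(F)cc2)c2ccc(F)cc2)CC1` is not yet measured; it arises from compound 2 by the change (tert-butyl in place of 4-fluorophenyl on a carbonyl carbon), the same change as that from compound 1 to compound 3, at a place described in identical terms. Within the data shown here, compound 2 is expected to move by a 4.5-fold higher number from compound 2 to compound 4 (0.65 log units; beyond the scatter), resting on the single earlier step of a 5.1-fold higher number from compound 1 to compound 3 (0.71 log units; beyond the scatter); with one precedent only, the expectation is loose. For compound 4 in this assay the estimate is 6500 nM, within 2800 nM to 15000 nM.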

Compound 4, inhibition constant: 11200 nM
Compound 4: the middle estimate sits 1.7-fold (0.24 log units) below what was measured; the measured number falls inside the stated range.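

In this assay, tert-butyl in place of 4-fluorophenyl on a carbonyl carbon gives a 7.8-fold higher number from compound 2 to compound 4 (0.89 log units; beyond the scatter) on the second core as well, and the two steps agree: the same change on two cores in this assay, a 5.1-fold higher number (0.71 log units; beyond the scatter) from compound 1 to compound 3 and a 7.8-fold higher number (0.89 log units; beyond the scatter) from compound 2 to compound 4, 1.5-fold (0.19 log units) apart, within the scatter of two such steps. The change therefore carries from the core of compound 1 to the core of compound 2 in this assay, with no sign that its size depends on the core. This rests on two pairs and a single change, so it does not show that the step would hold on further cores, for other groups or in other assays.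

Still open, as far as these compounds go, is whether other groups on the carbonyl, such as cyclohexyl or a pyridine, follow the same course. Also open, from the compounds shown here alone, is whether the step survives on a core carrying a sulfone.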